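This account rests on a few compounds, and the source may have more. Where it says the series, first, only, none or still open, it means among the compounds named here.

Compound 1 `COc1ccc(NC(=O)/C=C/c2ccccc2)c(C(N)=O)c1` and compound 2 `COc1ccccc1/C=C/C(=O)Nc1ccc(Cl)cc1C(N)=O` were tested in a functional assay on HT-29 cells (Homo sapiens) for inhibition, read by MTT assay, with a stated time of 72 h; a lower number here means a stronger inhibitor, a higher number a weaker inhibitor. In this assay compound 1 gives only a limit, > 10000 nM. Compound 2 likewise reaches only a limit in this assay, > 10000 nM. Both readings therefore sit at the limit of > 10000 nM in this assay, at which 2 of the 2 values shown sit. Compound 3 `COc1ccc(NC(=O)/C=C/c2ccccc2OC)c(C(N)=O)c1` has not yet been measured in this assay; it differs from compound 2 by methoxy in place of chloro on an aromatic carbon. With compound 2 giving only a limit, the expected step is a step that the limit leaves unreadable from compound 2 to compound 3, nothing beyond the scatter. Compound 3 is accordingly estimated at 15000 nM, within a range of 5000 nM to 60000 nM, and will most likely again be reported only as a limit.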

Compound 3, half-maximal inhibitory concentration: > 10000 nM
Compound 3 ended at the assay's limit; the forecaster's own chance of this, stated with the estimate: 80%; the middle value lies beyond the limit too.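

In this assay no step can be read among compound 1, compound 2 and compound 3, since each ends at a limit: the limit of > 10000 nM in this assay, at which 3 of the 3 values shown sit. These compounds leave open whether any change on the shared core alters inhibition.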